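The source may hold more compounds than are shown below. What is called first, only, known or untested is meant among the compounds shown, and "the series" means these compounds.

In a functional assay on the whole organism with Mus musculus as the target (on this read-out higher numbers stand for an effect only at larger amounts of compound and lower numbers for an effect already at smaller amounts), compound 1 `CCn1c(=O)[nH]c2c(ncn2C2O[C@H](CO)[C@@H](O)[C@H]2O)c1=N` gives only a limit, > 100 mg/kg. Compound 2 `Cn1c(=O)[nH]c2c(nc(Br)n2C2O[C@H](CO)[C@@H](O)[C@H]2O)c1=N` also gives only a limit, > 100 mg/kg. Compound 3 `Cn1c(=O)[nH]c2c(nc(NN)n2C2O[C@H](CO)[C@@H](O)[C@H]2O)c1=N` likewise gives only a limit, > 100 mg/kg, so it has no number that fixes its place in the series. The same holds across the set: the limit of > 100 mg/kg in this assay, at which 3 of the 3 values shown sit.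

Compound 4 `Cn1c(=O)[nH]c2c(nc(N)n2C2O[C@H](CO)[C@@H](O)[C@H]2O)c1=N` differs from compound 3 by a single change, hydrogen in place of amino on a nitrogen on an aromatic ring, or aminoamino to amino when cut one bond further out. Going by the values given here, the one measured step touching this group is a step that the two limits leave unreadable from compound 2 to compound 3, and it offers no size to carry over. No readable step therefore supports a shift in either direction in this assay, and none beyond the scatter is expected. The estimated step is a step that the limit leaves unreadable from compound 3 to compound 4, and a further limit remains the likeliest read-out. For compound 4 the expected value is 130 mg/kg, with an estimated range from 40 mg/kg to 400 mg/kg.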

Compound 4, dose for half-maximal effect: > 100 mg/kg
Compound 4 ended at the assay's limit (the forecaster's own chance of this, stated with the estimate: 70%); the middle value does not contradict the limit.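

In this assay, going by these compounds alone, compound 4 also gives only a limit, so no step among compound 2, compound 3 and compound 4 can be read: the limit of > 100 mg/kg in this assay, at which 4 of the 4 values shown sit. The compounds shown leave open whether any change on the shared core gives a measurable half-maximal dose.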